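A Four-Atom Swap on the Shared Core

The source may report more compounds than this note shows. Statements on the series, on what has been measured and on what is new or still open speak of the compounds shown alone.

compound 1 `Oc1cccc2c1nc(-c1c(F)cccc1F)n2Cc1c(F)cccc1F` — > 100 uM
compound 2 `CC(=O)Nc1cccc2c1nc(-c1c(F)cccc1F)n2Cc1c(F)cccc1F` — 39.3 uM
compound 3 `N=C(NO)c1cccc2c1nc(-c1c(F)cccc1F)n2Cc1c(F)cccc1F` — not yet measured

In a toxicity assay on CCRF-CEM cells (Homo sapiens) for cytotoxicity (a lower number here means that less compound is tolerated, a higher number that more compound is tolerated), compound 1 gives > 100 uM, a limit of the assay. In this assay, within the data shown here, compound 2 gives 39.3 uM, the only number so far. The value of compound 1 is a limit, (the limit of > 100 uM in this assay, at which 1 of the 2 values shown sits). Among the measured compounds shown here, the one measured step, an at least 2.5-fold lower number from compound 1 to compound 2 (0.40 log units; beyond the scatter), is the only evidence that bears on the change to compound 3: a group of 4 heavy atoms (1 carbon, 2 nitrogen, 1 oxygen; no ring) in place of a group of 4 heavy atoms (2 carbon, 1 nitrogen, 1 oxygen; no ring), on an aromatic carbon. It was modest, so little beyond the scatter is expected. Compound 3 is estimated at 40 uM, between 15 uM and 100 uM. That estimate means an expected 1.0-fold higher number from compound 2 to compound 3 (0.01 log units; within the scatter).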

Compound 3, half-maximal toxic concentration: 23.1 uM
The estimate for compound 3 lay 1.7-fold (0.24 log units) above the measured number; low and high end bracket the measured number.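

In this assay, the change at this aromatic carbon from acetamido to the new group gives a 1.7-fold lower number from compound 2 to compound 3 (0.23 log units; within the scatter), so the two groups are not told apart here, although the entering group has more hydrogen-bond donors and acceptors. Set against hydroxy, the new group gives an at least 4.3-fold lower number from compound 1 to compound 3 (0.63 log units; beyond the scatter), so a second group at this position now stands apart from hydroxy. Compound 1 stands at a limit of the assay: the limit of > 100 uM in this assay, at which 1 of the 3 values shown sits.

From the compounds shown here alone, whether an amine or a carboxylic acid at this aromatic carbon would follow hydroxy or the two larger groups stays open. So does what a longer chain would do here.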